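The compounds below may be only part of what the source reports. "The series", "measured", "known", "first", "only" and "open" are said of these compounds alone.

Measured so far in a functional assay for inhibition of beta-glucuronidase (Bos taurus), tested at 1 mM; a lower number here means a weaker effect, a higher number a stronger effect of the compound at the concentration tested:

- compound 1, `CN/N=C/c1ccc2ccc(=O)oc2c1`: compound 1 gives 93.3%
- compound 2, `O=c1ccc2ccc(/C=N/O)cc2o1`: compound 2 gives 100%
- compound 3, `O=c1ccc2ccc(/C=N/N=C/c3ccc4ccc(=O)oc4c3)cc2o1`: compound 3 gives 100%

Compound 1 holds the lowest of the three numbers, yet its gaps to compound 2 and to compound 3 both lie within the scatter, so no order among the three can be read from this assay; all three sit close to full inhibition at the tested concentration.

Within the data shown here, the only step measured between two compounds that differ in one place is a number 6.7 percentage points higher from compound 1 to compound 2 (within the scatter). Among the measured compounds shown here, compound 3 carries a second copy of the shared core in that same place and also gives a number within the scatter of compound 1, but no single-change step to it is available.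

Compound 4, `O=c1ccc2ccc(/C=N/c3ccccc3)cc2o1`, differs from compound 1 as follows: phenyl in place of methylamino on a double-bonded nitrogen. The change sits at the same double-bonded nitrogen as the step from compound 1 to compound 2, where the exchange of one group for another left the read-out within the scatter. The values of compound 3 point the same way. On that basis a step of a number 1.7 percentage points higher from compound 1 to compound 4 (within the scatter) is expected, that is, nothing beyond the scatter in either direction. Compound 4 is estimated at 95%, with a range from 85% to 100%.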

Compound 4, a percentage reported as inhibition, at one concentration (the size of the read-out at that concentration, not a potency): 95.4%
For compound 4 the middle estimate is 0.4 percentage points below the measured one; the range from low to high includes it.
By their numbers in this assay, from the lowest: compounds 1, 4, 2 and 3 (each within the scatter of the next).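

With phenyl as the new group on the double-bonded nitrogen, the read-out shows a number 2.1 percentage points higher from compound 1 to compound 4 (within the scatter) when methylamino leaves and a number 4.6 percentage points lower from compound 2 to compound 4 (within the scatter) when hydroxy leaves, both in this assay. Among these compounds, until now the only single-change step at this place ran from methylamino to hydroxy; these two steps add a group with one six-membered aromatic ring of carbon only and 0 hydrogen-bond donors and 0 hydrogen-bond acceptors, and neither step leaves the scatter, so among compounds 1, 2 and 4 neither the ring nor the count of donors and acceptors separates the read-outs. No measurement at hand bears on why the read-out shows no step beyond the scatter at this place.

As far as these compounds go, whether a carboxylic acid, an amine or a longer alkyl chain on the double-bonded nitrogen would leave the read-out within the scatter remains open. From the compounds shown here alone, all four compounds sit close to full inhibition at one concentration, so any difference in potency among them also remains open.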